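The compounds below may be only part of what the source reports. "The series", "measured", "known", "first", "only" and "open" are said of these compounds alone.

Two compounds sharing a common core have so far been examined in an ADME assay on HEK293 cells (Homo sapiens) for cytotoxicity, read by MTT assay; on this read-out higher numbers stand for weaker inhibition and lower numbers for stronger inhibition. Compound 1 `COc1ccc(-n2ncn(Cc3cn(Cc4cc5cc(Br)ccc5nc4Cl)nn3)c2=O)cc1` carries a bromo group on the fused two-ring system and gives 333 ug/mL in this assay. Compound 2 `COc1ccc(-n2ncn(Cc3cn(Cc4cc5ccccc5nc4Cl)nn3)c2=O)cc1`, in which hydrogen stands in place of that bromo, gives 958 ug/mL in this assay; it holds the higher of the two numbers recorded, with compound 1 nearest at the step of a 2.9-fold higher number from compound 1 to compound 2 (0.46 log units; beyond the scatter). Compound 3 `COc1ccc(-n2ncn(Cc3cn(Cc4cc5cc(Cl)ccc5nc4Cl)nn3)c2=O)cc1` has not yet been measured. It differs from compound 2 by chloro in place of hydrogen on an aromatic carbon. Among the compounds with values here, the only measured step that bears on this change is the replacement of bromo by hydrogen, a 2.9-fold higher number from compound 1 to compound 2 (0.46 log units; beyond the scatter), a modest step that lies beyond the scatter. Bringing a halogen back onto the same carbon, now chloro rather than bromo, is therefore expected to move the number back down in this assay, by an amount similar to or somewhat smaller than that step. Compound 3 is accordingly expected to give 450 ug/mL in this assay, with a range from 250 ug/mL to 850 ug/mL, which corresponds to an expected step of a 2.1-fold lower number from compound 2 to compound 3 (0.33 log units; beyond the scatter).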

Compound 3, half-maximal inhibitory concentration: 1060 ug/mL
The estimate for compound 3 lay 2.4-fold (0.37 log units) below the measured number, and the stated range ends below it.
By their numbers in this assay, from the lowest: compound 1; then compounds 2 and 3 (each within the scatter of the next).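

In this assay, chloro in place of hydrogen on this aromatic carbon gives a 1.1-fold higher number from compound 2 to compound 3 (0.04 log units; within the scatter), so the presence of a halogen here does not by itself separate compound 3 from compound 2, and the lower number of compound 1 is tied to bromo rather than to halogens at this carbon in general. Chloro in place of bromo gives a 3.2-fold higher number from compound 1 to compound 3 (0.50 log units; beyond the scatter) and is of about the same size as the earlier step of hydrogen in place of bromo, a 2.9-fold higher number from compound 1 to compound 2 (0.46 log units; beyond the scatter), so at this position the two halogens are not interchangeable and, of the three groups, only bromo stands apart. Nothing available explains why bromo and chloro differ at this carbon.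

From the compounds shown here alone, whether the lower number is particular to bromo or extends to a larger halogen such as iodo, or to other groups on this carbon such as methyl, methoxy or an amine, remains open. Going by these compounds, it also remains open whether bromo gives a similar step on the other carbons of this six-membered aromatic ring or when the remainder of the shared core is changed.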